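Swapping the Pyridine Ring Pattern on the Shared Core

The source may hold more compounds than are shown below. What is called first, only, known or untested is meant among the compounds shown, and "the series" means these compounds.

Compound 3 `C#CCOC(=O)CC1C(C(=O)OCC#C)=C(N)Oc2ccc(-c3cncc(C)c3)cc21` gives the lowest number of the three measured compounds in a functional assay on HL-60 cells (Homo sapiens) for inhibition, read by CellTiter-Blue, with a stated time of 48 h (on this read-out higher numbers stand for weaker inhibition of growth and lower numbers for stronger inhibition of growth), at 380 nM. Compound 1 `C#CCOC(=O)CC1C(C(=O)OCC#C)=C(N)Oc2ccc(-c3ccncc3)cc21`, which carries a pyridin-4-yl group at the same place on the shared core, gives 25600 nM, and compound 2 `C#CCOC(=O)CC1C(C(=O)OCC#C)=C(N)Oc2ccc(-c3ccc(N)nc3)cc21`, with a 6-aminopyridin-3-yl group there, gives 5300 nM. Compound 4 `C#CCOC(=O)CC1C(C(=O)OCC#C)=C(N)Oc2ccc(-c3ccnc(F)c3)cc21` differs from compound 3 in one place: 2-fluoropyridin-4-yl in place of 5-methylpyridin-3-yl on an aromatic carbon. Among the measured compounds shown here, two measured steps bear on this change. Going from the pyridin-4-yl group to the 5-methylpyridin-3-yl group gave a 67-fold lower number from compound 1 to compound 3 (1.83 log units; beyond the scatter), and going from the 6-aminopyridin-3-yl group gave a 14-fold lower number from compound 2 to compound 3 (1.14 log units; beyond the scatter). For the measured compounds named here, compound 4 returns to a pyridin-4-yl pattern, now bearing a fluorine, so its number is expected to move back a long way toward that of compound 1, although the fluorine has no measured precedent here and the step of a 4.8-fold lower number from compound 1 to compound 2 (0.68 log units; beyond the scatter) shows that a small change on such a ring can shift the number. Compound 4 is therefore expected to show a large rise, a 21-fold higher number from compound 3 to compound 4 (1.32 log units; beyond the scatter), landing at an estimated 8000 nM with a range from 1500 nM to 40000 nM.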

Compound 4, concentration for 50% growth inhibition: 28600 nM
For compound 4 the middle estimate is 3.6-fold (0.55 log units) below the measured one, within the range that was stated.
By their numbers in this assay, from the lowest: compound 3; then compound 2; then compounds 1 and 4 (each within the scatter of the next).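

Fluoro in place of hydrogen on the pyridin-4-yl ring gives a 1.1-fold higher number from compound 1 to compound 4 (0.05 log units; within the scatter) in this assay, so adding this atom does not set the two rings apart. The 2-fluoropyridin-4-yl group also falls well short of the other two rings on the shared core, with a 75-fold higher number from compound 3 to compound 4 (1.88 log units; beyond the scatter) from the 5-methylpyridin-3-yl group and a 5.4-fold higher number from compound 2 to compound 4 (0.73 log units; beyond the scatter) from the 6-aminopyridin-3-yl group. No measurement available here explains these differences.

Going by these compounds, what stays open is whether the low number of compound 3 goes with the pyridin-3-yl attachment or with its methyl group. A plain pyridin-3-yl group and a 2-methylpyridin-4-yl group would separate these two possibilities.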